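Cyclopentenone series: fluoro to hydroxy on the aryl ring

A few compounds are considered here, and "the series" means these few. Any claim that something is new, unique, unknown or untested is made for them only; others in the source may bear on it.

Measured compounds, with their values in an ADME assay on KB cells (Homo sapiens) for cytotoxicity, read by MTT assay, with a stated time of 72 h; on this read-out lower numbers stand for stronger inhibition and higher numbers for weaker inhibition:
- compound 1, `COc1ccc(C2=C(c3cc(OC)c(OC)c(OC)c3)C(=O)C(OC(C)=O)C2)cc1F`: compound 1 gives 33 ug/mL
- compound 2, `COCOc1cc(C2=C(c3cc(OC)c(OC)c(OC)c3)C(=O)CC2O[SiH2]C(C)(C)C)ccc1OC`: compound 2 gives 33 ug/mL
- compound 3, `COc1ccc(C2=C(c3cc(OC)c(OC)c(OC)c3)C(=O)CC2C)cc1C(=O)O`: compound 3 gives > 100 ug/mL, which is a limit of the assay and not a number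

Compound 1 stands level with compound 2 at the digits shown, the two values lying within the usual scatter of each other, so no order between them is read. The third value is a limit of > 100 ug/mL in this assay, at which 1 of the 3 values shown sits, and gives no number to place compound 1 against.

The next compound, compound 4, `COc1ccc(C2=C(c3cc(OC)c(OC)c(OC)c3)C(=O)C(OC(C)=O)C2)cc1O`, differs from compound 1 in one place: hydroxy in place of fluoro on an aromatic carbon. The change is counted as one heavy atom leaving and one heavy atom entering, with one hydrogen-bond donor and one hydrogen-bond acceptor entering.

Among the compounds with values here, no measured step in this set involves a hydroxy in place of a fluoro, so the size of the step is not anchored by a comparison. Compound 2, which carries an ether in the corresponding place, gives 33 ug/mL, level with compound 1, and this suggests a modest change at most. The step from compound 1 to compound 4 is expected to be a 1.3-fold lower number from compound 1 to compound 4 (0.12 log units; within the scatter), within or close to the scatter. Compound 4 is estimated at 25 ug/mL, between 8 ug/mL and 70 ug/mL.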

Compound 4, half-maximal inhibitory concentration: 35 ug/mL
Compound 4: the middle estimate sits 1.4-fold (0.15 log units) below what was measured, within the range that was stated.
By their numbers in this assay, from the lowest: compounds 1, 2 and 4 (each within the scatter of the next). At a limit, above all of these: compound 3.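

In this assay, the change from 3-fluoro-4-methoxyphenyl to 3-hydroxy-4-methoxyphenyl gives a 1.1-fold higher number from compound 1 to compound 4 (0.03 log units; within the scatter). Within the data shown here, this is the first reading of a single change at this place on the aromatic ring with the rest of compound 1 held fixed. Hydroxy in place of fluoro brings in a hydrogen-bond donor and a hydrogen-bond acceptor, yet the number stays within the scatter, so on this core the read-out does not separate the two groups. Nothing measured here bears on why the step is so small.

Compound 3 carries a carboxylic acid at this place but also differs from compound 1 elsewhere on the core, so it gives no single-change reading of this position, and its value is only a limit of the assay. As far as these compounds go, whether an amine or a longer alkoxy chain at this place would move the number beyond the scatter stays open, as does whether hydroxy and fluoro would still read alike on a core without the acetoxy group.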